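The compounds below may be only part of what the source reports. "The series", "measured", "known", "first", "only" and "open" are said of these compounds alone.

Going by the values given here, compound 1, with the structure `CCCc1ccc(/C=C/C(=O)Nc2ccc3nc(CCC)cc(N)c3c2)cc1`, is one of three compounds measured in a functional assay on HEK293 cells for activation of melanin-concentrating hormone receptor 1 (Homo sapiens), read by inositol phosphate accumulation (a lower number here means that less compound is needed, a higher number that more compound is needed for the effect), where it gives 3600 nM. That is the highest number of the three. Compound 3, `CCCc1cc(NC2CCC2)c2cc(NC(=O)/C=C/c3ccc(C(F)(F)F)cc3)ccc2n1`, gives 270 nM, and compound 2, `CC(C)(C)c1cc(N)c2cc(NC(=O)/C=C/c3ccc(C(F)(F)F)cc3)ccc2n1`, gives 29 nM; both gaps to compound 1 lie beyond the scatter, and compound 1 is the least potent of the set. Compounds 2 and 3 each carry a trifluoromethyl group in place of the propyl group of compound 1, but they also differ from it elsewhere, so no single change can be read from them.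

Compound 4, `CCCc1cc(N)c2cc(NC(=O)/C=C/c3ccc(F)cc3)ccc2n1`, has not yet been measured. It differs from compound 1 in one spot: fluoro in place of propyl on an aromatic carbon. Since compounds 2 and 3, which also lack the propyl group, show lower numbers, the step from compound 1 to compound 4 is expected to move downward by a moderate amount, a 4.5-fold lower number from compound 1 to compound 4 (0.65 log units; beyond the scatter). The value expected for compound 4 in this assay is 800 nM, within a range from 250 nM to 3000 nM.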

Compound 4, half-maximal effective concentration: 200 nM
Beside the measured number, compound 4's estimate is 4.0-fold (0.60 log units) above it; measured number outside the range, below it.
By their numbers in this assay, from the lowest: compound 2; then compounds 4 and 3 (each within the scatter of the next); then compound 1.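

In this assay, swapping 4-propylphenyl for 4-fluorophenyl, with the rest of the structure unchanged, gives an 18-fold lower number from compound 1 to compound 4 (1.26 log units; beyond the scatter) and so shows that this one position, on an aromatic carbon para to a large group, can by itself shift the number substantially. The earlier compounds shown here could not show this, as each differed from compound 1 in more than one place. Three carbons leave and one fluorine enters, with no change in the counted hydrogen-bond donors or acceptors, and nothing available explains the drop.

As far as these compounds go, whether fluoro itself matters or simply losing propyl is enough remains open, and a hydrogen, a chloro, a methoxy or a longer chain at this position would help separate the two. Steps linking compounds 2 and 3 to the others cannot be read, so the effect of trifluoromethyl here also stays unresolved.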